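Pyrazole attachment point on a fused bicyclic series

The source may report more compounds than this note shows. Statements on the series, on what has been measured and on what is new or still open speak of the compounds shown alone.

Of the compounds shown here, three have been measured in a functional assay on CHO cells for agonist activity at Alpha-1A adrenergic receptor (Homo sapiens), read by FLIPR and calcium flux; on this read-out higher numbers stand for larger maximal responses and lower numbers for smaller maximal responses. Compound 1 `Clc1ccc2c(c1-c1ccn[nH]1)CCC2c1ncc[nH]1` gives 40% in this assay. Compound 2 `Cn1cc(-c2cccc3c2CCC3c2ncc[nH]2)cn1` gives 12% in this assay, the lowest of the three numbers; compound 1 stands higher by more than the scatter, and compound 3 `CCS(=O)(=O)Nc1cccc(Cc2c[nH]cn2)c1`, which gives 96% in this assay, stands furthest above it. For the measured compounds named here, no pair of measured compounds differs in only one place, so no single-change step has been measured.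

Compound 4 `Cn1nccc1-c1cccc2c1CCC2c1ncc[nH]1` has not been measured. It shares its atoms with compound 2, joined differently: 1-methyl-1H-pyrazol-5-yl in place of 1-methyl-1H-pyrazol-4-yl on an aromatic carbon. Compound 1 also carries a pyrazolyl group joined through the carbon next to the ring nitrogen, and its value of 40% sits above compound 2, but compound 1 differs in other places too, so this is only a loose pointer.

For compound 4 a small rise in this assay is expected, a number 13 percentage points higher from compound 2 to compound 4 (beyond the scatter), a step that may not exceed the scatter. Compound 4 is estimated at 25%, within a range from 5% to 55%.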

Compound 4, largest response reached (Emax), in percent of the reference or control that the assay uses: 58%
The estimate for compound 4 lay 33 percentage points below the measured number; the whole stated range lies below it.
By their numbers in this assay, from the lowest: compound 2; then compound 1; then compound 4; then compound 3.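

Replacing 1-methyl-1H-pyrazol-4-yl with 1-methyl-1H-pyrazol-5-yl on this aromatic carbon gives a number 46 percentage points higher from compound 2 to compound 4 (beyond the scatter) in this assay. For the compounds shown here, this is the first single-change step, and it shows that the way the pyrazole is joined to the shared core is enough on its own to shift the maximal response, since both groups have the same heavy atoms, hydrogen-bond donor and acceptor counts, and net charge. Going by these compounds alone, nothing measured so far explains the size of this step.

As far as these compounds go, it remains open whether the step would persist with an ethyl group or a hydrogen in place of the methyl on the pyrazole nitrogen. Also unresolved is how an amine or a carboxylic acid on the pyrazole ring would affect the maximal response in either attachment.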